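Taking the bromo off compound 3

The source may report more compounds than this note shows. Statements on the series, on what has been measured and on what is new or still open speak of the compounds shown alone.

In a functional assay on SK-MEL-2 cells (Homo sapiens) for cytotoxicity (on this read-out higher numbers stand for weaker inhibition and lower numbers for stronger inhibition), compound 1 `Cc1ccc(C2CN(S(=O)(=O)c3ccccc3)C(=O)N2)cc1` gives > 316000 nM, which is a limit of the assay and not a number. Compound 2 `Cc1ccc(S(=O)(=O)N2CC(c3ccc(Br)cc3)NC2=O)cc1` gives > 253000 nM, which is also a limit. Among the measured compounds shown here, compound 3 `O=C1NC(c2ccc(Br)cc2)CN1S(=O)(=O)c1ccc2c(c1)CCC2` gives 32600 nM, the only true number among the three values so far. Compound 4 `O=C1NC(c2ccccc2)CN1S(=O)(=O)c1ccc2c(c1)CCC2` differs from it by one change, hydrogen in place of bromo on an aromatic carbon, para to a large group (hydrogen in place of bromo on an aromatic carbon). For the measured compounds named here, no measured pair shows this swap alone, so any forecast is uncertain. The expected result is a modest weakening, a 1.8-fold higher number from compound 3 to compound 4 (0.26 log units; within the scatter). Compound 4 is estimated at 60000 nM, with an expected range from 20000 nM to 200000 nM.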

Compound 4, half-maximal inhibitory concentration: 2 nM
Compound 4: the middle estimate sits 30000-fold (4.48 log units) above what was measured; the measured number lies below the stated range.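

Going from 4-bromophenyl to phenyl gives a 16000-fold lower number from compound 3 to compound 4 (4.21 log units; beyond the scatter) in this assay, a size of change the earlier compounds could not reveal, as only compound 3 had given a true number. This place on the aromatic ring, para to a large group, is therefore highly sensitive: a single bromine atom separates a weak compound from a very strong one. As far as these compounds go, whether a fluoro group, a methoxy group or an amine at this place would keep that strength stays open. Nothing shown gives a reason for a step of this size.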